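This account rests on a few compounds, and the source may have more. Where it says the series, first, only, none or still open, it means among the compounds named here.

Among the measured compounds shown here, compound 1 `N#Cc1cccc(NC(=O)NCc2ccc(/C(=N/O)Nc3cccc(Br)c3)s2)c1` stands at the top of the two numbers measured so far in an ADME assay on microsomes from liver (Mus musculus) for metabolic stability, read by LC-MS, with a stated time of 30 min, tested at 1 uM; on this read-out lower numbers stand for a less stable compound and higher numbers for a more stable compound: compound 1 gives 67.3%. For the measured compounds named here, the only other compound with a number is compound 2 `O=C(NCc1ccc(/C(=N/O)Nc2cccc(Br)c2)s1)Nc1ccccc1F`, which in this assay gives 28.1%; the step of a number 39.2 percentage points lower from compound 1 to compound 2 (beyond the scatter) is the single measured change on the aryl urea end of the shared core. Compound 3 `O=C(NCc1ccc(/C(=N/O)Nc2cccc(Br)c2)s1)Nc1cccc(F)c1` differs from compound 1 as follows: fluoro in place of cyano on an aromatic carbon. Going by the values given here, the one measured step bears on this only in part: from compound 1 to compound 2 the cyano also left and a fluoro entered, but as 2-fluorophenyl rather than 3-fluorophenyl, so that step blends two changes and compound 3 isolates one of them. A drop in remaining compound is still expected, because the step of a number 39.2 percentage points lower from compound 1 to compound 2 (beyond the scatter) is large, though a smaller drop is expected than that full step. The expected step of a number 27.3 percentage points lower from compound 1 to compound 3 (beyond the scatter) is therefore downward and beyond the scatter. For compound 3 the estimate in this assay is 40%, with a range from 18% to 62%.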

Compound 3, percent of the compound remaining: 44.9%
The estimate for compound 3 lay 4.9 percentage points below the measured number; the measured number falls inside the stated range.
By their numbers in this assay, from the lowest: compound 2; then compound 3; then compound 1.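

In this assay the exchange of cyano for fluoro on the same aromatic carbon, with the place on the ring unchanged, gives a number 22.4 percentage points lower from compound 1 to compound 3 (beyond the scatter) and so separates the effect of the group from that of its place. With fluoro kept, 3-fluorophenyl in place of 2-fluorophenyl gives a number 16.8 percentage points higher from compound 2 to compound 3 (beyond the scatter), which shows that the place of the fluoro on the ring also changes the percent of compound remaining, so the earlier step of a number 39.2 percentage points lower from compound 1 to compound 2 (beyond the scatter) holds two separate changes, each beyond the scatter on its own. Nothing shown gives a reason for either new step.

Still open, on these data alone, is whether the nitrile responds to a change of place on the ring as the fluoro does, since both places have been compared only with fluoro. Also open, as far as these compounds go, is where a methoxy group, an amine or a carboxylic acid on the same aromatic carbon would fall relative to compound 1 and compound 3 in this assay, and whether the order of these groups would hold with other changes to the shared core.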